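Trimethoxyphenyl in Place of Phenylethenyl on a Silent Series

A few compounds are considered here, and "the series" means these few. Any claim that something is new, unique, unknown or untested is made for them only; others in the source may bear on it.

Compound 1, `Cc1cc(O)c(C2=NN(c3ccc(S(N)(=O)=O)cc3)C(c3ccccc3O)C2)cc1Cl`, gives > 100000 nM in a functional assay on K562 cells (Homo sapiens) for antiproliferative activity, with a stated time of 48 h (a higher number here means that more compound is tolerated, a lower number that less compound is tolerated), which is a limit of the assay rather than a number.
Compound 2, `Cc1cc(O)c(C2=NN(c3ccc(S(N)(=O)=O)cc3)C(c3ccccc3Cl)C2)cc1Cl`, gives > 100000 nM in this assay, again a limit.
Compound 3, `Cc1cc(O)c(C2=NN(c3ccc(S(N)(=O)=O)cc3)C(/C=C/c3ccccc3)C2)cc1Cl`, gives > 100000 nM in this assay, also a limit.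

Compound 3 therefore stands nowhere readable: its value is a limit, and the same holds for both other compounds, as the limit of > 100000 nM in this assay, at which 3 of the 3 values shown sit, shows. Compound 4, `COc1ccc(C2CC(c3cc(Cl)c(C)cc3O)=NN2c2ccc(S(N)(=O)=O)cc2)c(OC)c1OC`, differs from compound 3 by 2,3,4-trimethoxyphenyl in place of 2-phenylethenyl on a saturated ring carbon. The measured steps that bear on this change are those to and from compound 3 and between the other two: a step that the two limits leave unreadable from compound 1 to compound 3, a step that the two limits leave unreadable from compound 2 to compound 3 and a step that the two limits leave unreadable from compound 1 to compound 2. None of them has a readable size, because every value sits at the limit of > 100000 nM in this assay, at which 3 of the 3 values shown sit. No direction or size can be expected from these data, and a result at the limit is the most likely outcome again. Compound 4 is therefore estimated at 100000 nM, with a range from 30000 nM to 300000 nM. The expected step from compound 3 to compound 4 is a number no higher from compound 3 to compound 4 (the limit leaves the size open), an estimate with no measured support for any change.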

Compound 4, concentration lethal to 50% of the cells: > 100000 nM
Compound 4: a limit, no number; the forecaster's own chance of this, stated with the estimate: 75%; the middle value sits exactly at the limit.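

Compound 4 gives a limit of the assay rather than a number, as do compound 1, compound 2 and compound 3, so no step to compound 4 can be read: the limit of > 100000 nM in this assay, at which 4 of the 4 values shown sit.

In this assay these four compounds leave open whether any group on this saturated ring carbon changes the result.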